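Aryl amide change from compound 2 to compound 3

This account rests on a few compounds, and the source may have more. Where it says the series, first, only, none or still open, it means among the compounds named here.

Measured so far in an in vitro ADME assay on microsomes from liver (Mus musculus) for pharmacokinetics, read by LC-MS, with a stated time of 10 min, tested at 1 uM; a lower number here means slower removal, a higher number faster removal of the compound:
- compound 1 `COc1ccc(NC(=O)[C@H]2CN(C)C[C@@H]2c2ccc(/C=C/C(=O)Nc3ccccc3N)cc2)cc1` - 54 mL/min/kg
- compound 2 `COc1cccc(NC(=O)[C@H]2CN(C)C[C@@H]2c2ccc(/C=C/C(=O)Nc3ccccc3N)cc2)c1` - 65 mL/min/kg

In this assay compound 2 stands at 65 mL/min/kg, within the scatter of compound 1. Compound 3 `CN1C[C@H](C(=O)Nc2ccccc2F)[C@@H](c2ccc(/C=C/C(=O)Nc3ccccc3N)cc2)C1`, not yet measured, carries 2-fluorophenyl in place of 3-methoxyphenyl on an amide-type nitrogen. Among the compounds with values here, the only measured step at this place is a 1.2-fold higher number from compound 1 to compound 2 (0.08 log units; within the scatter), and it exchanges 4-methoxyphenyl for 3-methoxyphenyl. Within the data shown here, no measured compound carries 2-fluorophenyl, so this single step is limited evidence and gives no direction. A change beyond the scatter is therefore not expected, though the range is kept wide. The expected step is a 1.1-fold lower number from compound 2 to compound 3 (0.05 log units; within the scatter), none beyond the scatter. Compound 3 is estimated at 58 mL/min/kg, with an expected range of 30 mL/min/kg to 105 mL/min/kg.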

Compound 3, clearance: 67 mL/min/kg
Beside the measured number, compound 3's estimate is 1.2-fold (0.06 log units) below it; low and high end bracket the measured number.
By their numbers in this assay, from the lowest: compounds 1, 2 and 3 (each within the scatter of the next).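

In this assay, 2-fluorophenyl on the amide-type nitrogen gives a 1.0-fold higher number from compound 2 to compound 3 (0.01 log units; within the scatter) against 3-methoxyphenyl, and a 1.2-fold higher number from compound 1 to compound 3 (0.09 log units; within the scatter) against 4-methoxyphenyl. The position has now taken a ring without methoxy, carrying fluorine instead, and all three aryl amides remain within the scatter of one another, so the earlier comparison of the two methoxy placements extends to a different substituent on the ring. No measurement at hand accounts for this lack of separation.

On these data alone, it remains open whether the same holds when the aryl ring on this nitrogen gives way to a cyclohexyl group, or when the ring carries an amine or a carboxylic acid. Also open, as far as these compounds go, is whether any change at this position can move the clearance beyond the scatter, or whether changes to the shared core would be needed.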